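The source may hold more compounds than are shown below. What is called first, only, known or untested is meant among the compounds shown, and "the series" means these compounds.

In a functional assay on thoracic aorta (Rattus norvegicus, strain Wistar), with a stated time of 15 min (on this read-out higher numbers stand for an effect only at larger amounts of compound and lower numbers for an effect already at smaller amounts), the values so far are:
compound 1 `CC(NC(=O)NS(=O)(=O)c1ccc(Cl)cc1)c1cc(Br)ccc1OCc1ccccc1` gives 57500 nM
compound 2 `Cc1ccc(OCc2ccccc2)c(C(C)NC(=O)NS(=O)(=O)c2ccc(Cl)cc2)c1` gives 65300 nM
compound 3 `COc1ccc(Br)cc1C(C)NC(=O)NS(=O)(=O)c1ccccc1` gives > 300000 nM (a limit)

Going by the values given here, compound 2 and compound 1 hold the only two numbers, and these lie within the scatter of each other. The reading for compound 3 is a limit and not a number.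

Compound 4 `CC(NC(=O)NS(=O)(=O)c1ccc(Cl)cc1)c1ccccc1OCc1ccccc1` comes from compound 2 by one change hydrogen in place of methyl on an aromatic carbon (hydrogen in place of methyl on an aromatic carbon, para to a benzyloxy group). Among the compounds with values here, with a 1.1-fold higher number from compound 1 to compound 2 (0.06 log units; within the scatter) (methyl in place of bromo) as the one measured step on that carbon, no step beyond the scatter is expected in this assay in either direction. The estimated step is a 1.1-fold higher number from compound 2 to compound 4 (0.06 log units; within the scatter) for this change. For compound 4 the expected value is 75000 nM with an estimated range of 32000 nM to 180000 nM in this read-out.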

Compound 4, half-maximal effective concentration: 157000 nM
Compound 4: the middle estimate sits 2.1-fold (0.32 log units) below what was measured; the measured number falls inside the stated range.
By their numbers in this assay, from the lowest: compounds 1 and 2 (each within the scatter of the next); then compound 4. At a limit, above all of these: compound 3.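

In this assay, methyl and bromo on this carbon, para to a benzyloxy group, could not be told apart, but hydrogen there separates from both (a 2.4-fold higher number from compound 2 to compound 4 (0.38 log units; beyond the scatter); a 2.7-fold higher number from compound 1 to compound 4 (0.44 log units; beyond the scatter)). For these two groups, then, a substituent on this carbon goes with an effect at smaller amounts of compound than hydrogen does, though both steps are modest. Nothing in hand accounts for this difference.

From the compounds shown here alone, whether an amine or a carboxylic acid on this carbon would read like methyl and bromo or like hydrogen remains open.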